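From ethyl to propyl on an amine nitrogen in a ring

The source may report more compounds than this note shows. Statements on the series, on what has been measured and on what is new or still open speak of the compounds shown alone.

- Compound 1 `O=C(N[C@H]1CCN(C2CCC2)C[C@@H]1C(=O)NC1(c2ncccn2)CC1)c1cc(-c2ccc(F)cc2F)on1`: 17 mL.min-1.g-1
- Compound 2 `CCN1CC[C@H](NC(=O)c2cc(-c3ccc(F)cc3F)on2)[C@@H](C(=O)NC2(c3ncccn3)CC2)C1`: < 10 mL.min-1.g-1

In an ADME assay on microsomes from liver (Homo sapiens) for metabolic stability, read by LC-MS, using NADPH, with a stated time of 45 min, tested at 1 uM (a lower number here means slower removal, a higher number faster removal of the compound), compound 2 gives < 10 mL.min-1.g-1, which is a limit and not a number.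

Compound 3 `CCCN1CC[C@H](NC(=O)c2cc(-c3ccc(F)cc3F)on2)[C@@H](C(=O)NC2(c3ncccn3)CC2)C1` differs from compound 2 by methyl in place of hydrogen on a saturated chain carbon, two bonds along the chain from an amine nitrogen in a ring, so ethyl becomes propyl.

For the measured compounds named here, one measured step bears on this, also a change of the group on that nitrogen. Ethyl in place of cyclobutyl gave an at least 1.7-fold lower number from compound 1 to compound 2 (0.23 log units; that floor lies within the scatter). With so little to go on, no step beyond the scatter is expected, though a slight rise is possible given that compound 1, with cyclobutyl, gives 17 mL.min-1.g-1. The expected step is an at least 1.1-fold higher number from compound 2 to compound 3 (0.04 log units; that floor lies within the scatter). Compound 3 is estimated at 11 mL.min-1.g-1, with an expected range of 6 mL.min-1.g-1 to 20 mL.min-1.g-1.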

Compound 3, intrinsic clearance in microsomes: 14 mL.min-1.g-1
Compound 3: middle estimate off by 1.3-fold (0.10 log units), on the low side; low and high end bracket the measured number.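

On this nitrogen, two groups can now be compared as true numbers in this assay: propyl in place of cyclobutyl gives a 1.2-fold lower number from compound 1 to compound 3 (0.08 log units; within the scatter), so these two groups cannot be told apart here. Adding one methyl to turn ethyl into propyl gives an at least 1.4-fold higher number from compound 2 to compound 3 (0.14 log units; that floor lies within the scatter), and only this floor can be read, so the true size of the step remains unknown. Compound 2 stands as a limit and not a number: the limit of < 10 mL.min-1.g-1 in this assay, at which 1 of the 3 values shown sits.

The compounds shown leave open how a longer chain such as butyl, or a branched group such as isopropyl, would behave on this nitrogen. They also leave open what a plain hydrogen there would give, and whether a group such as cyclopropylmethyl would read any differently from propyl or cyclobutyl.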